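The compounds below may be only part of what the source reports. "The series", "measured", "known", "first", "only" and "open" are said of these compounds alone.

In a functional assay on HEK293 cells (Homo sapiens) for cytotoxicity (a lower number here means that less compound is tolerated, a higher number that more compound is tolerated), compound 1 (`COc1ccc([C@H]2CC(=O)N(c3cccc(C(F)(F)F)c3)C2)cc1OC1CCCC1`) reads > 10000 nM as a limit of the assay and not a number. Compound 2 (`COc1ccc([C@H]2CC(=O)N(c3cccc(NCC4CCOC4)c3)C2)cc1OC1CCCC1`) reads > 10000 nM as a limit too, so its standing is known only as that limit. Both measured compounds sit at the same limit (the limit of > 10000 nM in this assay, at which 2 of the 2 values shown sit). Among the compounds with values here, the one measured step that the two limits leave unreadable from compound 1 to compound 2 bears on the next change, yet it has no readable size and gives no direction.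

Compound 3 (`COc1ccc([C@H]2CC(=O)N(c3cccc(NC(=O)C(C)=O)c3)C2)cc1OC1CCCC1`) has acetylcarbonyl in place of (oxolan-3-yl)methyl on a nitrogen on an aromatic ring. Within the data shown here, with no sized step to build on, no step beyond the scatter is expected in this assay and compound 3 is expected to stay near the limit of compound 2. The expected step is a step that the limit leaves unreadable from compound 2 to compound 3 as an estimate only. For compound 3 the estimated value is 14000 nM with an expected range of 5000 nM to 40000 nM in this estimate.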

Compound 3, half-maximal cytotoxic concentration: > 10000 nM
Compound 3: only a limit was reported (the forecaster's own chance of this, stated with the estimate: 80%); the middle value is on the limit's open side.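

In this assay compound 3 gives > 10000 nM, a limit of the assay and not a number, so the steps from compound 1 and compound 2 to compound 3 cannot be read. The compounds shown leave open whether they differ at all in this read-out, since all share one limit: the limit of > 10000 nM in this assay, at which 3 of the 3 values shown sit.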